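Trimming the selenium side group of compound 1

A few compounds are considered here, and "the series" means these few. Any claim that something is new, unique, unknown or untested is made for them only; others in the source may bear on it.

In a functional assay on LoVo cells (Homo sapiens) for inhibition, read by MTT assay, with a stated time of 48 h (on this read-out higher numbers stand for weaker inhibition and lower numbers for stronger inhibition), compound 1 `COc1ccc(N(C)c2nc(C)nc3ccccc23)cc1C(=O)OCCC[Se]C#N` gives 854 nM and sits within the scatter of compound 2 `Cc1nc(N(C)c2ccc(OCC[Se]C#N)cc2)c2ccccc2n1` at 547 nM on the same read-out. Compound 3 `Cc1nc(N(C)c2ccc([Se]C#N)c(Cl)c2)c2ccccc2n1` gives 12 nM and this number lies far below both of those values.

Compound 4 `COc1ccc(N(C)c2nc(C)nc3ccccc23)cc1C[Se]C#N` has not yet been measured. Its change from compound 1 is a group of 4 heavy atoms (2 carbon, 1 nitrogen, 1 selenium; no ring) in place of a group of 9 heavy atoms (5 carbon, 1 nitrogen, 2 oxygen, 1 selenium; no ring), on an aromatic carbon and it sits ortho to a methoxy group and meta to a large group. Going by the values given here, the set holds no step between measured compounds that differ in one place, so this change has no direct precedent. Among the compounds with values here, the only low number so far belongs to compound 3 (12 nM) and that compound lacks the longer chains of compound 1 and compound 2, which points only loosely towards a lower number here. The expected change is an 8.5-fold lower number from compound 1 to compound 4 (0.93 log units; beyond the scatter) towards stronger inhibition and is estimated to lie beyond the scatter. For compound 4 the estimate is 100 nM (expected range 25 nM to 400 nM).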

Compound 4, half-maximal inhibitory concentration: 277 nM
Estimate against measurement, compound 4: 2.8-fold (0.44 log units) below; the measured number falls inside the stated range.
By their numbers in this assay, from the lowest: compound 3; then compounds 4, 2 and 1 (each within the scatter of the next, the first and the last beyond it).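

In this assay, the group of 4 heavy atoms in place of the group of 9 heavy atoms, on an aromatic carbon ortho to a methoxy group, gives a 3.1-fold lower number from compound 1 to compound 4 (0.49 log units; beyond the scatter). Going by these compounds alone, this is the first step between compounds that differ in one place, and it shows that the number responds to the selenium side group at this position, moving modestly towards stronger inhibition with the smaller group. No measurement at hand accounts for this step.

Still open, going by these compounds, is whether the step follows the shorter chain or the loss of the carbonyl: a plain carbon chain of intermediate length at this position would separate the two. Also open, on these data alone, is whether the selenium side group can give way here to an amine or a carboxylic acid.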